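The compounds below may be only part of what the source reports. "The series", "measured", "known", "first", "only" and "open" are said of these compounds alone.

Measured in a functional assay on L1210 cells (Mus musculus) for cytotoxicity; a lower number here means a stronger inhibitor, a higher number a weaker inhibitor:
compound 1 `O=C(/C=C/C(=O)N1C/C(=C\c2ccccc2)C(=O)/C(=C/c2ccccc2)C1)Nc1ccc([N+](=O)[O-])cc1` gives 40000 nM
compound 2 `CC(=O)c1ccc(NC(=O)/C=C/C(=O)N2C/C(=C\c3ccccc3)C(=O)/C(=C/c3ccccc3)C2)cc1` gives 5500 nM
compound 3 `Cc1ccc(NC(=O)/C=C/C(=O)N2C/C(=C\c3ccccc3)C(=O)/C(=C/c3ccccc3)C2)cc1` gives 5800 nM

Compound 3 stands second highest of the three numbers: compound 2 is its nearest, within the scatter, while a 6.9-fold lower number from compound 1 to compound 3 (0.84 log units; beyond the scatter) is a clear gap. Compound 4 `Cc1ccc(NC(=O)/C=C/C(=O)N2C/C(=C\c3ccccc3)C(=O)/C(=C/c3ccccc3)C2)cc1C` differs from compound 3 by methyl in place of hydrogen on an aromatic carbon. For the measured compounds named here, no measured step adds a second group to this ring; the steps that bear on it are swaps of the group on the same ring, a 7.3-fold lower number from compound 1 to compound 2 (0.86 log units; beyond the scatter) and a 6.9-fold lower number from compound 1 to compound 3 (0.84 log units; beyond the scatter), both modest, and a 1.1-fold higher number from compound 2 to compound 3 (0.02 log units; within the scatter), within the scatter. The added methyl is therefore expected to move this assay little, with no direction beyond the scatter, so the expected step is a 1.2-fold lower number from compound 3 to compound 4 (0.06 log units; within the scatter). Compound 4 is estimated at 5000 nM, in the range 2500 nM to 12000 nM.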

Compound 4, half-maximal inhibitory concentration: 31000 nM
Compound 4: middle estimate off by 6.2-fold (0.79 log units), on the low side, outside the stated range (above it).
By their numbers in this assay, from the lowest: compounds 2 and 3 (each within the scatter of the next); then compounds 4 and 1 (each within the scatter of the next).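

In this assay, the change from 4-methylphenyl to 3,4-dimethylphenyl is not silent at this position: one added methyl, ortho to a methyl group, gives a 5.3-fold higher number from compound 3 to compound 4 (0.73 log units; beyond the scatter), a modest step like the earlier swaps on this ring. Replacing 4-acetylphenyl gives a similar result, a 5.6-fold higher number from compound 2 to compound 4 (0.75 log units; beyond the scatter), while replacing 4-nitrophenyl gives a 1.3-fold lower number from compound 1 to compound 4 (0.11 log units; within the scatter), which is within the scatter. No measurement available here accounts for the step.

Going by these compounds, whether the step requires the neighbouring methyl remains open, as does how an amine or a carboxylic acid at this place would read.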